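Swapping fluoro for iodo on a diaryl urea

The compounds below may be only part of what the source reports. "The series", "measured", "known", "first", "only" and "open" are said of these compounds alone.

Measured compounds:
- Compound 1, `Cc1ccc(NC(=O)N[C@H](C)c2ccccc2)cc1`: 64%
- Compound 2, `CCCc1ccc(NC(=O)N[C@H](C)c2ccccc2)cc1`: 35%
- Compound 3, `C[C@@H](NC(=O)Nc1ccc(F)cc1)c1ccccc1`: 92%

All three share one core, a urea linking a substituted aromatic ring to a phenyl-bearing chiral carbon, and they were compared in an ADME assay on the whole organism with Oryza sativa as the target, tested at 10 uM; on this read-out higher numbers stand for a weaker effect at the one concentration tested and lower numbers for a stronger effect. Compound 3 stands highest of the three numbers: the step of a number 28 percentage points higher from compound 1 to compound 3 (beyond the scatter) separates it from compound 1, and the step of a number 57 percentage points higher from compound 2 to compound 3 (beyond the scatter) from compound 2. Within the measured set, every change at the substituted aromatic carbon moved the read-out beyond the scatter, and fluoro gave the weakest effect.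

Compound 4, `C[C@@H](NC(=O)Nc1ccc(I)cc1)c1ccccc1`, has not yet been measured. It differs from compound 3 in one place: iodo in place of fluoro on an aromatic carbon, on an aromatic carbon of a six-membered aromatic ring of carbon only, para to a large group.

Among the compounds with values here, the steps that bear on this are those ending at compound 3, since both also exchange the group at this same position: a number 28 percentage points higher from compound 1 to compound 3 (beyond the scatter) was modest, and a number 57 percentage points higher from compound 2 to compound 3 (beyond the scatter) was large. Both replacements of fluoro by another group lowered the number. Because compound 1 gave 64% and compound 2 gave 35% with other groups at this carbon, a lower number for iodo is expected, so the step of a number 32 percentage points lower from compound 3 to compound 4 (beyond the scatter) is estimated to fall beyond the scatter. For compound 4 the expected value is 60%, within a range from 35% to 85%.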

Compound 4, a percentage reported as activity, at one concentration (the size of the read-out at that concentration, not a potency): 85%
Compound 4: the middle estimate sits 25 percentage points below what was measured; the measured number falls inside the stated range.
By their numbers in this assay, from the lowest: compound 2; then compound 1; then compounds 4 and 3 (each within the scatter of the next).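

In this assay, the step of a number 7 percentage points lower from compound 3 to compound 4 (within the scatter) shows that fluoro and iodo cannot be told apart at this aromatic carbon, so the lower numbers seen with methyl and propyl do not extend to every replacement of fluoro. Iodo remains clearly separate from both carbon chains, with a number 21 percentage points higher from compound 1 to compound 4 (beyond the scatter) and a number 50 percentage points higher from compound 2 to compound 4 (beyond the scatter). Across these four compounds, the two halogens therefore group together at the high end of the read-out, meaning a weaker effect at the one concentration tested, while the two carbon chains give lower numbers, and no compound here goes against this split, although a set of four can support only a tentative pattern.

The compounds shown leave open whether chloro and bromo would group with fluoro and iodo, and whether a longer chain such as butyl, or a different kind of group such as an amine or a carboxylic acid, would give a number as low as propyl or lower still. Nothing given here accounts for the split between the halogens and the carbon chains.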